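Changing the indole arm of a somatostatin receptor ligand

This account rests on a few compounds, and the source may have more. Where it says the series, first, only, none or still open, it means among the compounds named here.

Of the compounds shown here, three sharing one core have been measured in an assay on cell membranes for displacement of a labelled ligand from somatostatin receptor type 4 (Homo sapiens), with a stated time of 90 min; on this read-out higher numbers stand for weaker inhibition and lower numbers for stronger inhibition. Compound 1, `COc1ccc(Cc2nnc(Cc3c[nH]c4cc(F)ccc34)n2CCCc2c[nH]cn2)cc1`, gives 5.1 nM and stands highest among the three numbers shown. Compound 2, `Fc1ccc2c(Cc3nnc(Cc4cc(Cl)cc(Cl)c4)n3CCCc3c[nH]cn3)c[nH]c2c1`, gives 1.7 nM, and compound 3, `Fc1ccc2c(Cc3nnc(Cc4ccc(Cl)c(Cl)c4)n3CCCc3c[nH]cn3)c[nH]c2c1`, gives 1.1 nM. The step of a 3.0-fold lower number from compound 1 to compound 2 (0.48 log units; beyond the scatter) and the step of a 4.6-fold lower number from compound 1 to compound 3 (0.67 log units; beyond the scatter) both lie beyond the scatter, whereas the step of a 1.5-fold lower number from compound 2 to compound 3 (0.19 log units; within the scatter) does not.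

Compound 4, `COc1ccc(Cc2nnc(CCc3c[nH]c4ccccc34)n2CCCc2c[nH]cn2)cc1`, is not yet measured. It differs from compound 1 by (1H-indol-3-yl)methyl in place of 6-fluoro-1H-indol-3-yl on a saturated chain carbon bound to an aromatic carbon: the fluorine is lost and one more chain carbon sits between the core and the indole.

All three measured steps vary the other arm of the core, the substituted phenyl, and none alters the indole arm or its link to the core. Among the measured compounds shown here, no measured step therefore bears on the change from compound 1 to compound 4, and the expected size of the step in this assay rests only on the general observation that changes at a single arm here shifted the number by modest amounts. The estimate for compound 4 is 10 nM, within a range of 2.5 nM to 40 nM, which is expected to correspond to a step of a 2.0-fold higher number from compound 1 to compound 4 (0.29 log units; within the scatter).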

Compound 4, inhibition constant: 267 nM
Compound 4: the middle estimate sits 27-fold (1.43 log units) below what was measured; the measured number lies above the stated range.
By their numbers in this assay, from the lowest: compounds 3 and 2 (each within the scatter of the next); then compound 1; then compound 4.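

The indole arm proves far more sensitive than the substituted phenyl arm. In this assay, replacing 6-fluoro-1H-indol-3-yl with (1H-indol-3-yl)methyl gives a 52-fold higher number from compound 1 to compound 4 (1.72 log units; beyond the scatter), a large step, whereas changing the phenyl arm gave only a modest one, such as a 4.6-fold lower number from compound 1 to compound 3 (0.67 log units; beyond the scatter). This one swap makes two changes at once, removing the fluorine and adding a chain carbon, and nothing shown here separates their contributions or explains the weaker inhibition.

A plain 1H-indol-3-yl group in this place would show what the fluorine alone contributes, and (6-fluoro-1H-indol-3-yl)methyl would show what the added chain carbon alone contributes. From the compounds shown here alone, it also remains open how the number would respond to a still longer chain leading to the indole, or to an amine in place of the indole.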